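The compounds below may be only part of what the source reports. "The series", "measured", "known", "first", "only" and "open" are said of these compounds alone.

Working notes on the series. The shared core is that of compound 2 `O=C(Nc1nn[nH]n1)c1cccc(-c2ccccc2)n1`, which in a functional assay on the whole organism for inhibition, with Rattus norvegicus as the target, at a dose of 10 mg/kg by the oral route (on this read-out lower numbers stand for a weaker effect and higher numbers for a stronger effect at the one dose given), gives 81%. On the numbers shown compound 2 stands second of three: compound 1 `COc1cc(C(=O)Nc2nn[nH]n2)nc(-c2ccc(NC(C)=O)cc2)c1`, which differs from it in two places, gives 100% in this assay, and compound 3 `COc1ccccc1-c1cccc(C(=O)Nc2nn[nH]n2)n1` gives 0%. Among the compounds with values here, the one single-place step recorded is a number 81 percentage points lower from compound 2 to compound 3 (beyond the scatter), a collapse of the read-out when a methoxy group enters on the phenyl group.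

Compound 4 `CCc1cc(C(=O)Nc2nn[nH]n2)nc(-c2ccccc2)c1` differs from compound 2 by ethyl in place of hydrogen on an aromatic carbon. Within the data shown here, no measured step puts a group on an aromatic carbon of the six-membered ring with one nitrogen, so the step from compound 2 to compound 3 bears on it only as a warning that a small added group on this core can erase activity; compound 1, with its two changes, shows that a substituted core can still read high. With the read-out of compound 2 already close to the top of the scale, a step of a number 16 percentage points lower from compound 2 to compound 4 (beyond the scatter) is expected, downward, with wide uncertainty. Compound 4 is estimated at 65%, in the range 15% to 100%.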

Compound 4, a percentage reported as inhibition, in the whole organism at one dose (the size of the read-out at that dose, not a potency): 85%
Beside the measured number, compound 4's estimate is 20 percentage points below it, within the range that was stated.
By their numbers in this assay, from the lowest: compound 3; then compounds 2 and 4 (each within the scatter of the next); then compound 1.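

Ethyl in place of hydrogen on the aromatic carbon opposite the ring nitrogen gives, in this assay, a number 4 percentage points higher from compound 2 to compound 4 (within the scatter), so this position carries ethyl without a change in the read-out beyond the scatter. An added group on the shared core therefore does not erase the read-out at every place: the collapse seen with methoxy on the phenyl group, a number 81 percentage points lower from compound 2 to compound 3 (beyond the scatter), does not recur with ethyl at this place. No measurement on hand bears on the reason for this result.

Open, on these data alone, is whether a longer chain, an amine or a carboxylic acid at this position would keep the read-out as ethyl does. Also open, as far as these compounds go, is how compound 2 and compound 4 compare at any other dose, as both read near the top of the scale at the one dose given.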